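A Chlorophenoxy Swap at the Chain of Compound 3

This account rests on a few compounds, and the source may have more. Where it says the series, first, only, none or still open, it means among the compounds named here.

Among the compounds with values here, in a functional assay on HepG2 cells (Homo sapiens) for cytotoxicity, read by MTT assay, with a stated time of 48 h (a higher number here means a weaker inhibitor, a lower number a stronger inhibitor), compound 3 `CC1=NN(C(=O)CCc2ccccc2)C(c2cc(Br)cc(Br)c2O)C1` gives 9170 nM, the lowest of the numbers so far. Compound 2 `CCC(=O)N1N=C(C)CC1c1cc(Br)cc(Br)c1O` gives 41400 nM, while compound 1 `CC1=NN(C(=O)COc2ccc(Cl)cc2)C(c2cc(Br)ccc2O)C1` is reported as "not active" (no number reported), without a number. Compound 4 `CC1=NN(C(=O)COc2ccc(Cl)cc2)C(c2cc(Br)cc(Br)c2O)C1` is unmeasured and has 4-chlorophenoxy in place of benzyl on a saturated chain carbon bound to a carbonyl carbon. Within the data shown here, the one measured step at this chain, a 4.5-fold lower number from compound 2 to compound 3 (0.65 log units; beyond the scatter), was modest, and it placed phenyl in place of hydrogen. It does not test this swap, although compound 1 also carries 4-chlorophenoxy. The expected step, a 1.3-fold higher number from compound 3 to compound 4 (0.12 log units; within the scatter), stays within the scatter, leaning towards a higher number. The estimated value for compound 4 is 12000 nM, with an expected range of 3500 nM to 40000 nM.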

Compound 4, half-maximal inhibitory concentration: "not active" (no number reported)
Compound 4: no number reported; no gap can be computed for the estimate.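

Within the data shown here, compound 4 has no number, and no step from compound 3 to compound 4 can be read. Nothing shown accounts for this result. From the compounds shown here alone, how far 4-chlorophenoxy in place of benzyl shifts the number in this assay stays open.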